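The source may report more compounds than this note shows. Statements on the series, on what has been measured and on what is new or still open speak of the compounds shown alone.

Measured so far:
- compound 1 `COc1cc2c(Oc3ccc(NC(=O)c4nnn(-c5ccccc5C)c4C)cc3F)ccnc2cc1OCCCN1CCCC1` gives 270 nM in a functional assay on MKN-45 cells (Homo sapiens) for cytotoxicity, read by MTT assay, with a stated time of 72 h; a higher number here means a weaker inhibitor, a lower number a stronger inhibitor
- compound 2 `COc1cc2c(Oc3ccc(NC(=O)c4nnn(-c5ccccc5)c4C)cc3F)ccnc2cc1OCCCN1CCCC1` gives 40 nM in this assay
- compound 3 `COc1cc2c(Oc3ccc(NC(=O)c4nnn(-c5ccc(F)cc5)c4C(F)(F)F)cc3F)ccnc2cc1OCCCN1CCCC1` gives 21 nM in this assay

Compound 3 holds the lowest of the three numbers; its gap to compound 2 lies within the scatter, while compound 1 stands clearly higher. Compound 4 `COc1cc2c(Oc3ccc(NC(=O)c4nnn(-c5ccc(C)cc5)c4C(F)(F)F)cc3F)ccnc2cc1OCCCN1CCCC1` differs from compound 3 by methyl in place of fluoro on an aromatic carbon. Going by the values given here, the only measured step, a 6.8-fold lower number from compound 1 to compound 2 (0.83 log units; beyond the scatter), concerns a methyl at another place on the same ring and removes rather than adds it, so it bears only loosely on this change; no measured pair swaps fluoro for methyl. The expected step is a 1.2-fold higher number from compound 3 to compound 4 (0.08 log units; within the scatter), not beyond the scatter in either direction. Compound 4 is therefore estimated at 25 nM, range 10 nM to 70 nM.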

Compound 4, half-maximal inhibitory concentration: 210 nM
For compound 4 the middle estimate is 8.4-fold (0.92 log units) below the measured one; the measured number lies above the stated range.
By their numbers in this assay, from the lowest: compounds 3 and 2 (each within the scatter of the next); then compounds 4 and 1 (each within the scatter of the next).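

In this assay the swap of 4-fluorophenyl to 4-methylphenyl gives a 10-fold higher number from compound 3 to compound 4 (1.00 log units; beyond the scatter), so this position, para to a large group, separates two single-atom substituents clearly. In both measured steps on this phenyl the compound carrying the methyl has the higher number, as also seen in a 6.8-fold lower number from compound 1 to compound 2 (0.83 log units; beyond the scatter), and no compound shown goes against this. Nothing available explains the size of the step. Open, going by these compounds, is whether the effect follows methyl specifically or extends to other groups at this position. A methoxy, an amine or a chlorine here would test that.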